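Shifting a methyl group on the triazole substituent

The source may report more compounds than this note shows. Statements on the series, on what has been measured and on what is new or still open speak of the compounds shown alone.

Four related compounds share a sulfonamide-linked core and differ only in two respects: which methylphenyl sits on an aromatic nitrogen, and how the rest of the core is joined. Compound 1 `Cc1ccccc1-n1cc(-c2ccccc2NS(=O)(=O)c2c[nH]c(=O)[nH]c2=O)nn1` and compound 2 `Cc1cccc(-n2cc(-c3ccccc3NS(=O)(=O)c3c[nH]c(=O)[nH]c3=O)nn2)c1` share one core; compound 3 `Cc1ccccc1-n1cc(-c2ccc(NS(=O)(=O)c3c[nH]c(=O)[nH]c3=O)cc2)nn1` and compound 4 `Cc1cccc(-n2cc(-c3ccc(NS(=O)(=O)c4c[nH]c(=O)[nH]c4=O)cc3)nn2)c1` share another. The difference between the two cores is not broken down here.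

Compound 1 was tested in an ADME assay on GES1 cells (Homo sapiens) for cytotoxicity, read by MTT assay, with a stated time of 24 h (a lower number here means that less compound is tolerated, a higher number that more compound is tolerated), and gives 19900 nM. Compound 2 gives 23700 nM in this assay. The change between them is 3-methylphenyl in place of 2-methylphenyl on an aromatic nitrogen, and it made a step of a 1.2-fold higher number from compound 1 to compound 2 (0.08 log units; within the scatter). Compound 3 was also tested in this assay, and for compound 3 the result was recorded as "not toxic" (no number reported).

Compound 4 carries the same change relative to compound 3, namely (3-methylphenyl in place of 2-methylphenyl on an aromatic nitrogen), at the same place on the shared core. Because the step from compound 1 to compound 2 was a 1.2-fold higher number from compound 1 to compound 2 (0.08 log units; within the scatter), a similarly small effect is expected here, so compound 4 is expected to behave much like compound 3 in this assay, with a good chance that again no number is reached. If a number does emerge, compound 4 is estimated to give about 60000 nM in this assay, with a range expected from 20000 nM to 200000 nM.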

Compound 4, half-maximal cytotoxic concentration: 28300 nM
Compound 4: the middle estimate sits 2.1-fold (0.33 log units) above what was measured; the measured number falls inside the stated range.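

In this assay, going by these compounds alone, compound 4 gives 28300 nM, but compound 3 has only a verbal result and no number, so no step from compound 3 to compound 4 can be read. The compounds shown leave open how much 3-methylphenyl in place of 2-methylphenyl matters on the core of compound 3. Nothing shown here offers an explanation for the value of compound 4.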